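Swapping Methyl for Nitro: Expected Cytotoxicity of Compound 4

This account rests on a few compounds, and the source may have more. Where it says the series, first, only, none or still open, it means among the compounds named here.

Of the compounds shown here, three sharing one core have been tested in an ADME assay on MT4 cells (Homo sapiens) for cytotoxicity, read by MTT assay, with a stated time of 5 days; on this read-out lower numbers stand for higher toxicity in this test and higher numbers for lower toxicity in this test. Compound 1 `Cc1ccc2nc(Nn3c(-c4ccc([N+](=O)[O-])cc4)nnc3-c3cccnc3)sc2c1` gives 64.4 ug/mL. Compound 2 `O=[N+]([O-])c1ccc(-c2nnc(-c3cccnc3)n2Nc2nc3ccc(Cl)cc3s2)cc1` gives 53.7 ug/mL. Compound 3 `Cc1cccc2sc(Nn3c(-c4ccc([N+](=O)[O-])cc4)nnc3-c3cccnc3)nc12` gives 13.5 ug/mL, the lowest of the three numbers and thus the strongest toxicity in this test; since the steps of a 4.8-fold lower number from compound 1 to compound 3 (0.68 log units; beyond the scatter) and a 4.0-fold lower number from compound 2 to compound 3 (0.60 log units; beyond the scatter) both lie beyond the scatter, compound 3 is the most toxic of the measured compounds.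

Compound 4 `O=[N+]([O-])c1ccc(-c2nnc(-c3cccnc3)n2Nc2nc3c([N+](=O)[O-])cccc3s2)cc1` differs from compound 3 in one place: nitro in place of methyl on an aromatic carbon. The closest measured parallel is a swap of one small group for another on the same carbon, the step of a 1.2-fold lower number from compound 1 to compound 2 (0.08 log units; within the scatter), which stayed within the scatter. The larger steps of a 4.8-fold lower number from compound 1 to compound 3 (0.68 log units; beyond the scatter) and a 4.0-fold lower number from compound 2 to compound 3 (0.60 log units; beyond the scatter) involve a change in where the group sits on the fused ring rather than a change in its identity, so they bear less on this case. For the measured compounds named here, no measured compound carries a nitro group on this ring, so the expectation rests on the one substituent swap alone. The step of a 1.1-fold lower number from compound 3 to compound 4 (0.05 log units; within the scatter) is therefore expected to fall within the scatter. Compound 4 is estimated at 12 ug/mL, with a range from 5 ug/mL to 30 ug/mL.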

Compound 4, half-maximal cytotoxic concentration: 13.8 ug/mL
Estimate against measurement, compound 4: 1.2-fold (0.06 log units) below; the measured number falls inside the stated range.
By their numbers in this assay, from the lowest: compounds 3 and 4 (each within the scatter of the next); then compounds 2 and 1 (each within the scatter of the next).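

In this assay, nitro in place of methyl on this aromatic carbon gives a 1.0-fold higher number from compound 3 to compound 4 (0.01 log units; within the scatter), so the two numbers lie within the scatter of each other even though three heavy atoms with two hydrogen-bond acceptors replace a single carbon with none. The earlier swap of methyl for chloro, a 1.2-fold lower number from compound 1 to compound 2 (0.08 log units; within the scatter), also stayed within the scatter, but it lay on a different carbon of the fused ring; the new pair extends that picture to this position, ortho to a fused ring and meta to a fused ring, and to a larger entering group. No measurement shown explains why methyl and nitro read alike here.

Only methyl and nitro are shown at this position, so how an amine, a carboxylic acid or a longer chain would read there remains open. As far as these compounds go, it also remains open whether nitro would read the same on the carbon that holds methyl in compound 1, where a single swap would test whether this match depends on position.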